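Removing the methoxy from the aryl group of compound 1

The source may hold more compounds than are shown below. What is called first, only, known or untested is meant among the compounds shown, and "the series" means these compounds.

Compound 1 `COc1ccc(-c2[nH]c3ccccc3c2/C=C(\C#N)S(=O)(=O)c2ccccc2)cc1` gives 535 nM in a functional assay on K562 cells (Homo sapiens) for inhibition, read by sulforhodamine B assay, with a stated time of 48 h (a higher number here means a weaker inhibitor of growth, a lower number a stronger inhibitor of growth), the highest of the three numbers recorded; compound 2 `COc1ccc(-c2[nH]c3ccc(OC)cc3c2/C=C(\C#N)S(=O)(=O)c2ccccc2)cc1` gives 508 nM and compound 3 `COc1ccc(-c2[nH]c3ccc(OC)cc3c2C=C(C#N)C#N)cc1` gives 345 nM, both within the scatter of compound 1. Compound 4 `N#C/C(=C\c1c(-c2ccccc2)[nH]c2ccccc12)S(=O)(=O)c1ccccc1` carries hydrogen in place of methoxy on an aromatic carbon. Within the data shown here, the only measured step that touches a methoxy group, a 1.1-fold lower number from compound 1 to compound 2 (0.02 log units; within the scatter), adds one at a different place and changes nothing beyond the scatter. Among the measured compounds shown here, no step removes the methoxy that compound 4 lacks, so the expectation rests on that single step. Compound 4 is therefore expected to stay close to compound 1, with a 1.1-fold higher number from compound 1 to compound 4 (0.05 log units; within the scatter). The estimated value of compound 4 in this assay is 600 nM, with a range from 250 nM to 1500 nM.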

Compound 4, concentration for 50% growth inhibition: 348 nM
Beside the measured number, compound 4's estimate is 1.7-fold (0.24 log units) above it; the measured number falls inside the stated range.
By their numbers in this assay, from the lowest: compounds 3, 4, 2 and 1 (each within the scatter of the next).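

In this assay the change from 4-methoxyphenyl to phenyl gives a 1.5-fold lower number from compound 1 to compound 4 (0.19 log units; within the scatter) and so stays within the scatter. Unlike the earlier step, which added a methoxy elsewhere on the core, this one shows that the methoxy on the aromatic carbon para to a large group can give way to hydrogen with no change beyond the scatter. No measurement here offers an explanation for this result.

As far as these compounds go, whether an amine, a carboxylic acid or a longer alkoxy chain at this position would move the number beyond the scatter remains open.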